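Swapping Isopropyl for Cyclopentyl on the Ring Nitrogen

A few compounds are considered here, and "the series" means these few. Any claim that something is new, unique, unknown or untested is made for them only; others in the source may bear on it.

In an assay on isolated protein (Oryctolagus cuniculus) with Thromboxane-A synthase (Homo sapiens) as the target, tested at 1 uM (a higher number here means more inhibition at the concentration tested (going by the name of the read-out), a lower number less inhibition), compound 2 `CC(C)n1nc(-c2cccnc2)c2ccccc2c1=O` gives 87%, the highest of the three values measured. Compound 3 `C=CCn1nc(-c2cccnc2)c2ccccc2c1=O` gives 70% in this assay, and compound 1 `Oc1nnc(-c2cccnc2)c2ccccc12`, which carries no group on that nitrogen, gives 26%. Compound 4 `O=c1c2ccccc2c(-c2cccnc2)nn1C1CCCC1` has not yet been measured; it differs from compound 2 in one place: cyclopentyl in place of isopropyl on an aromatic nitrogen. Among the measured compounds shown here, the only measured step at this position is a number 17 percentage points lower from compound 2 to compound 3 (beyond the scatter), a modest change for a modest swap of group. Both isopropyl and cyclopentyl are built of carbon only, so the step of a number 5 percentage points lower from compound 2 to compound 4 (within the scatter) is expected to stay within the usual scatter. Compound 4 is therefore estimated at 82%, with a likely range from 65% to 95%.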

Compound 4, a percentage reported as inhibition, at one concentration (the size of the read-out at that concentration, not a potency): 97%
For compound 4 the middle estimate is 15 percentage points below the measured one, and the stated range ends below it.
By their numbers in this assay, from the lowest: compound 1; then compound 3; then compounds 2 and 4 (each within the scatter of the next).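

In this assay there is a number 10 percentage points higher from compound 2 to compound 4 (within the scatter), so a five-membered carbon ring on the aromatic nitrogen does as well as isopropyl. Cyclopentyl also shows a number 27 percentage points higher from compound 3 to compound 4 (beyond the scatter), which leaves allyl as the one group of these three that stands apart on this nitrogen. No measurement available explains this difference between the groups.

Still open, going by these compounds, is whether a six-membered ring such as cyclohexyl, or a longer carbon chain, would keep this level. A group bearing an amine or a carboxylic acid on this nitrogen is also untested in the compounds shown.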